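Ring swap beside the sulfonyl: compound 1 to compound 4

This account rests on a few compounds, and the source may have more. Where it says the series, first, only, none or still open, it means among the compounds named here.

Measured so far:
compound 1 `O=S(=O)(CC1=NCCS1)c1c(-c2ccccc2)nn(-c2ccccc2)c1-c1ccccc1` — "not active" (no number reported)
compound 2 `O=S(=O)(CC1=NCCS1)c1c(-c2ccc(Cl)cc2)nn(-c2ccccc2)c1-c1ccc(Cl)cc1` — "not active" (no number reported)
compound 3 `Cc1ccc(C2CNN=C2S(=O)(=O)CC2=NCCO2)cc1` — 42.1%

In a functional assay, tested at 75 ug/mL (a higher number here means a stronger effect of the compound at the concentration tested, a lower number a weaker effect), compound 1 gives "not active" (no number reported), so it stands without a single number; compound 2 is the one further entry without a number, and only compound 3 carries a number, giving 42.1% in this assay. Compound 4 `O=S(=O)(CC1=NCCO1)c1c(-c2ccccc2)nn(-c2ccccc2)c1-c1ccccc1` differs from compound 1 by a group of 5 heavy atoms (3 carbon, 1 nitrogen, 1 oxygen; one five-membered non-aromatic ring with 2 hetero atoms) in place of a group of 5 heavy atoms (3 carbon, 1 nitrogen, 1 sulfur; one five-membered non-aromatic ring with 2 hetero atoms), on a saturated chain carbon bound to a sulfonyl sulfur. The entering ring carries an oxygen where the leaving ring carries a sulfur; the same oxygen-bearing ring appears in compound 3, whose core otherwise differs, so nothing here fixes the size of the step. For the measured compounds named here, with no step between measured compounds to lean on, the change from compound 1 to compound 4 is expected to move this assay little, if at all, beyond the scatter, with any movement more likely upward than downward. Compound 4 is therefore expected to give about 15% in this assay, within a range from 0% to 45%.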

Compound 4, a percentage reported as activity, at one concentration (the size of the read-out at that concentration, not a potency): 57.3%
Estimate against measurement, compound 4: 42.3 percentage points below; the whole stated range lies below it.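

In this assay compound 1 gives "not active" (no number reported) and compound 4 gives 57.3% so no step can be read between them. The size of the change from the sulfur-bearing ring to the oxygen-bearing ring stays open, and nothing at hand bears on a cause.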